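Trimming the amino-acid side chain down to hydrogen

This account rests on a few compounds, and the source may have more. Where it says the series, first, only, none or still open, it means among the compounds named here.

Compound 3, `NC(=O)C[C@H](NC(=O)CN(c1nc(Cl)nc2[nH]cnc12)C1CC1)C(=O)O`, carries a carbamoylmethyl group on the saturated chain carbon bound to an amide-type nitrogen and a carbonyl carbon. Going by the values given here, in a functional assay on the whole organism (Tail, strain ICR) with Mus musculus as the target, in the tail flick test, with a stated time of 30 min, at a dose of 25 umol/kg by the oral route (on this read-out lower numbers stand for a weaker effect and higher numbers for a stronger effect at the one dose given), compound 3 gives 29.7%, the lowest of the three numbers measured so far, though within the scatter of both others. Its nearest neighbour, compound 1, `CC[C@H](C)[C@H](NC(=O)CN(c1nc(Cl)nc2[nH]cnc12)C1CC1)C(=O)O`, gives 30.3% in this assay, and the furthest, compound 2, `O=C(CN(c1nc(Cl)nc2[nH]cnc12)C1CC1)N[C@@H](CO)C(=O)O`, gives 38.7%. All three measured steps concern the same position: a number 8.4 percentage points higher from compound 1 to compound 2 (within the scatter), a number 0.6 percentage points lower from compound 1 to compound 3 (within the scatter) and a number 9 percentage points lower from compound 2 to compound 3 (within the scatter). None rises above the scatter, so exchanging sec-butyl, hydroxymethyl and carbamoylmethyl at that carbon has left this read-out where it was. Compound 4, `O=C(O)CNC(=O)CN(c1nc(Cl)nc2[nH]cnc12)C1CC1`, goes one step further: hydrogen in place of carbamoylmethyl on a saturated chain carbon bound to an amide-type nitrogen and a carbonyl carbon. The measured steps bear on this change only indirectly, since none removes the substituent altogether, but they give no sign that the group sets the size of the read-out. The step from compound 3 to compound 4 is therefore expected to be small, a number 2.3 percentage points higher from compound 3 to compound 4 (within the scatter), with no direction beyond the scatter. For compound 4 in this assay the estimated value is 32%, with a range from 18% to 46%.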

Compound 4, a percentage reported as activity, at one dose (the size of the read-out at that dose, not a potency): 32.2%
Beside the measured number, compound 4's estimate is 0.2 percentage points below it, and the stated range covers the measured number.
By their numbers in this assay, from the lowest: compounds 3, 1, 4 and 2 (each within the scatter of the next).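

Taking the substituent away altogether, a change none of the earlier steps made, leaves the read-out in this assay within the scatter of all three substituted compounds (a number 2.5 percentage points higher from compound 3 to compound 4 (within the scatter); a number 6.5 percentage points lower from compound 2 to compound 4 (within the scatter); a number 1.9 percentage points higher from compound 1 to compound 4 (within the scatter)). Hydrogen, with no heavy atom, thus joins sec-butyl, hydroxymethyl and carbamoylmethyl on the saturated chain carbon bound to an amide-type nitrogen and a carbonyl carbon, and across these four compounds no substituent there is needed to hold the read-out at this level. No evidence is available that would explain this insensitivity.

The compounds shown leave open whether a side chain ending in an amine or a carboxylic acid, a benzyl group or a longer alkyl chain at this carbon would move the read-out beyond the scatter, and whether the opposite arrangement at that carbon would do so. Since the read-out comes from a single dose at a single time, it also leaves open whether these four compounds would still stay together at other doses or times.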